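The source may report more compounds than this note shows. Statements on the series, on what has been measured and on what is new or still open speak of the compounds shown alone.

Measured compounds:
- compound 2 `Cc1ccccc1-c1nc(CN2CCC(C(=O)NCCCN3CCC(C(C)C)CC3)CC2)c(C)o1`: 396 10^-6 cm/s
- compound 3 `Cc1ccccc1-c1nc(CN2CCC(C(=O)N3CCN(CCN(C)C)CC3)CC2)c(C)o1`: 14 10^-6 cm/s
- compound 1 `Cc1ccc(C)c(-c2nc(CN3CCC(C(=O)NCCCN4C[C@H](C)C[C@H](C)C4)CC3)c(C)o2)c1`: "not determined" (no result reported)

In a physicochemical assay for permeability, using PAMPA (a higher number here means that the compound crosses the layer faster, a lower number that the compound crosses the layer more slowly), compound 2 gives 396 10^-6 cm/s, and compound 3 gives 14 10^-6 cm/s. For compound 1 no single number stands in this assay, so its position among these values cannot be stated; it shares the amide-linked propyl chain ending in a saturated ring with compound 2, whereas compound 3 carries a different amide part.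

Compound 4 `COc1cccc(Br)c1-c1nc(CN2CCC(C(=O)NCCCN3C[C@H](C)C[C@H](C)C3)CC2)c(C)o1` differs from compound 1 in one place: 2-bromo-6-methoxyphenyl in place of 2,5-dimethylphenyl on an aromatic carbon. The rest of the molecule, including the amide and the chain it carries, is unchanged. Since compound 1 has no number, the step cannot be sized against it; the expectation for compound 4 rests on compound 2 with its 396 10^-6 cm/s, which shares the same amide and chain, and the change of one aromatic substituent pattern for another is expected to shift the result by no more than the usual scatter. Compound 4 is therefore estimated at 300 10^-6 cm/s, with a range from 100 10^-6 cm/s to 700 10^-6 cm/s.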

Compound 4, apparent permeability: 245 10^-6 cm/s
Estimate against measurement, compound 4: 1.2-fold (0.09 log units) above; measured number inside the range.
By their numbers in this assay, from the lowest: compound 3; then compounds 4 and 2 (each within the scatter of the next).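

In this assay, among these compounds, compound 4 gives 245 10^-6 cm/s but yields no new step: compound 1, which differs from it in one place, holds no single number. The compounds shown leave open how 2-bromo-6-methoxyphenyl compares with 2,5-dimethylphenyl, and they offer no explanation for the value of compound 4.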